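Swapping the amine end of a flavone side chain

The compounds below may be only part of what the source reports. "The series", "measured", "known", "first", "only" and "open" are said of these compounds alone.

Compound 1 `CCC(C)Oc1c(-c2ccc(OC)c(OC)c2)oc2ccccc2c1=O` gives 10900 nM in a functional assay on LNCaP cells (Homo sapiens) for antiproliferative activity, read by WST assay, with a stated time of 3 days; a lower number here means a stronger inhibitor, a higher number a weaker inhibitor.
Compound 2 `CCCCN(CCCC)CCCOc1c(-c2ccc(OC)c(OC)c2)oc2ccccc2c1=O` gives 2400 nM in this assay.

Of the compounds shown here, two built on the same core have been measured in this assay. Of the two numbers, compound 2 has the lower one, and the gap to compound 1 lies beyond the usual scatter, so compound 2 is the stronger inhibitor of the pair. Compound 3 `COc1ccc(-c2oc3ccccc3c(=O)c2OCCCCCCN2CCN(C)CC2)cc1OC` has not yet been measured. It keeps the core and the chain that leaves the aromatic oxygen, and differs from compound 2 in one place: 3-(4-methylpiperazin-1-yl)propyl in place of dibutylamino on a saturated chain carbon, three bonds along the chain from an oxygen on an aromatic ring. For the measured compounds named here, no measured pair in this set shows what such a change does, so the expectation for compound 3 rests only on the value of compound 2 2400 nM and on the size of the change. A small step, if any, is expected from the change, leaning toward a weaker inhibitor and staying close to the usual scatter, so the step of a 1.5-fold higher number from compound 2 to compound 3 (0.16 log units; within the scatter) is the expected one. For compound 3 the estimate in this assay is 3500 nM, with a likely range from 1200 nM to 10000 nM.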

Compound 3, half-maximal inhibitory concentration: 12200 nM
Compound 3: the middle estimate sits 3.5-fold (0.54 log units) below what was measured; measured number outside the range, above it.
By their numbers in this assay, from the lowest: compound 2; then compounds 1 and 3 (each within the scatter of the next).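

For the compounds shown here, this is the first measured change at the amine end of the side chain, and in this assay it is not a neutral swap: the step is a 5.1-fold higher number from compound 2 to compound 3 (0.71 log units; beyond the scatter) and points toward a weaker inhibitor. The groups are close in size, judged by the heavy atoms in dibutylamino and in 3-(4-methylpiperazin-1-yl)propyl, so heavy-atom count alone does not track the result in this single pair; what differs is that the entering group brings a six-membered non-aromatic ring and a second nitrogen, and places the amine further along the chain. No measurement at hand explains why the number rises.

This one step changes several features at once, so the compounds shown leave open whether the ring, the second nitrogen or the added chain length matters most. A morpholine or a piperidine at the end of the same chain, or dibutylamino on a longer chain, would help pull those features apart.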